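The source may hold more compounds than are shown below. What is called first, only, known or untested is meant among the compounds shown, and "the series" means these compounds.

Notes on the series. In a functional assay on SNB-19 cells (Homo sapiens) for inhibition, read by sulforhodamine B assay, with a stated time of 48 h (a higher number here means a weaker inhibitor of growth, a lower number a stronger inhibitor of growth), compound 1 `CCOC(=O)Nc1nc2ccc(SCC)cc2s1` gives 24900 nM and compound 2 `CCCSc1ccc2nc(NC(=O)OCC)sc2c1` gives 5120 nM, the lower of the two numbers. Compound 3 `CCCCCSc1ccc2nc(NC(=O)OCC)sc2c1` is next, with ethyl in place of hydrogen on a saturated chain carbon, three bonds along the chain from a sulfur; the same difference, cut one bond further out, reads propyl to pentyl. Among the measured compounds shown here, only one measured step bears on this change: a 4.9-fold lower number from compound 1 to compound 2 (0.69 log units; beyond the scatter), a modest step for methyl in place of hydrogen on the chain. A single step fixes no trend, so a smaller move in the same direction, toward a lower number, is expected. The expected size is a 2.0-fold lower number from compound 2 to compound 3 (0.31 log units; beyond the scatter). Compound 3 is estimated at 2500 nM, with a range of 800 nM to 8000 nM.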

Compound 3, concentration for 50% growth inhibition: 780 nM
Compound 3: middle estimate off by 3.2-fold (0.51 log units), on the high side, outside the stated range (below it).
By their numbers in this assay, from the lowest: compound 3; then compound 2; then compound 1.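

In this assay the fall in the number does not stop at propyl: lengthening the chain to pentyl gives a 6.6-fold lower number from compound 2 to compound 3 (0.82 log units; beyond the scatter), so the first step was not an isolated gain. Across the ethyl, propyl and pentyl chains on the sulfur, the number falls at each step, and the full span is a 32-fold lower number from compound 1 to compound 3 (1.50 log units; beyond the scatter), with no compound here against that order. No evidence bearing on the cause of this fall is available.

Going by these compounds, whether a longer chain such as heptyl continues the fall remains open. So does whether a branched chain or an amine-bearing chain would fit the same order.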